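The source may hold more compounds than are shown below. What is called first, only, known or untested is meant among the compounds shown, and "the series" means these compounds.

Measured so far in a functional assay on PC-3 cells (Homo sapiens) for antiproliferative activity, read by sulforhodamine B assay; a higher number here means a weaker inhibitor of growth, a lower number a stronger inhibitor of growth:
- compound 1 `COc1cccc(OCCC(C)(C)C)c1C(=O)/C=C/c1ccc(O)cc1`: > 30000 nM (a limit)
- compound 2 `CC(C)(C)CCOc1cccc(O)c1C(=O)/C=C/c1ccc(C(=O)O)cc1`: 6500 nM
- compound 3 `CCCCCCOc1cccc(O)c1C(=O)/C=C/c1ccc(O)cc1`: > 30000 nM (a limit)

Compound 3 stands at the limit of > 30000 nM in this assay, at which 2 of the 3 values shown sit. Its entry is a limit and not a number. Among the measured compounds shown here, compound 2 is the only compound of the three with a numerical value, and no measured pair here differs in one place only.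

The next compound is compound 4 `CC(C)=CCOc1cccc(O)c1C(=O)/C=C/c1ccc(O)cc1`. The change from compound 3 is 2-methylprop-1-en-1-yl in place of pentyl on a saturated chain carbon bound to an oxygen on an aromatic ring. In words, this is 2-methylprop-1-en-1-yl in place of pentyl on a saturated chain carbon bound to an oxygen on an aromatic ring. Cut one bond further out, it reads hexyloxy to (3-methylbut-2-en-1-yl)oxy.

For the measured compounds named here, no measured step shows what this change does in this assay, so no step beyond the scatter is expected, in either direction. The expectation rests on compound 3, whose > 30000 nM is a limit and offers no number to step from. The expected step is a number no higher from compound 3 to compound 4 (the limit leaves the size open). A report of compound 4 as a limit only is about as likely as a numerical value. For compound 4 the estimated value is 30000 nM, with an expected range from 12000 nM to 60000 nM.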

Compound 4, concentration for 50% growth inhibition: > 30000 nM
Compound 4: a limit, no number; the forecaster's own chance of this, stated with the estimate: 55%; the middle value lies on the limit itself.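

No new step can be read from compound 3 to compound 4, since both stand as limits in this assay and the two limits leave the size unreadable: the limit of > 30000 nM in this assay, at which 3 of the 4 values shown sit.

The compounds shown leave open whether (3-methylbut-2-en-1-yl)oxy in place of hexyloxy changes growth inhibition at all, and in which direction.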